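One More Chain Carbon Toward the Hydroxamate

A few compounds are considered here, and "the series" means these few. Any claim that something is new, unique, unknown or untested is made for them only; others in the source may bear on it.

Four compounds share one core, seen in compound 1 `C#CCN(C)Cc1cccc(NC(=O)CCC(=O)NO)c1`, compound 2 `C#CCN(C)Cc1cccc(NC(=O)CCCCC(=O)NO)c1`, compound 3 `C#CCN(C)Cc1ccc(NC(=O)CCC(=O)NO)cc1` and the not yet measured compound 4 `C#CCN(C)Cc1ccc(NC(=O)CCCC(=O)NO)cc1`. They are compared in a functional assay on DU-145 cells (Homo sapiens) for inhibition, read by MTT assay, with a stated time of 48 h; on this read-out higher numbers stand for weaker inhibition of growth and lower numbers for stronger inhibition of growth.

Compound 1 reaches only a limit of the assay, > 10000 nM. Compound 2 gives 9750 nM. The step of an at least 1.0-fold lower number from compound 1 to compound 2 (0.01 log units; that floor lies within the scatter) is therefore no more than its floor, and that floor lies within the usual scatter. Compound 3 likewise reaches only a limit of the assay, > 10000 nM. For the measured compounds named here, two of the three values so far sit at that limit (the limit of > 10000 nM in this assay, at which 2 of the 3 values shown sit), so compound 3 stands where the assay stops reporting numbers, and no order between it and compound 1 can be read.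

The change to compound 4 is (hydroxycarbamoyl)methyl in place of hydroxycarbamoyl on a saturated chain carbon, two bonds along the chain from a carbonyl carbon. Going by the values given here, the one measured step of related kind, an at least 1.0-fold lower number from compound 1 to compound 2 (0.01 log units; that floor lies within the scatter), lengthened the same chain further than the present change does and still produced at most a shift inside the scatter. On that basis only a small step is expected, if any, in this assay.

Compound 4 is therefore expected to give about 9000 nM, within 3000 nM to 20000 nM, with a real chance that the assay again reports only a limit. The expected step of an at least 1.1-fold lower number from compound 3 to compound 4 (0.04 log units; that floor lies within the scatter) is estimated to lie within the scatter.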

Compound 4, concentration for 50% growth inhibition: > 10000 nM
Compound 4 gave a limit, no number (the forecaster's own chance of this, stated with the estimate: 55%); at least 1.1-fold (0.04 log units) between middle value and limit.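

In this assay, compound 4 gives > 10000 nM, which is a limit of the assay. Compound 3 gives > 10000 nM, also a limit. No step from one to the other can be read, as both values stand at the assay's end: the limit of > 10000 nM in this assay, at which 3 of the 4 values shown sit.

The compounds shown leave open whether (hydroxycarbamoyl)methyl in place of hydroxycarbamoyl changes growth inhibition at all in this assay.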